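Aryl Swap and Paw Edema Inhibition

The source may hold more compounds than are shown below. What is called first, only, known or untested is meant among the compounds shown, and "the series" means these compounds.

compound 1 `Cc1cc(C2=NN(c3ccc(S(C)(=O)=O)cc3)C(=O)CC2)ccc1O` — 26.6%
compound 2 `CS(=O)(=O)c1ccc(N2N=C(c3ccc(Cl)c(Cl)c3)CCC2=O)cc1` — 26.6%

In a functional assay on the whole organism (strain Wistar) for inhibition, with Rattus norvegicus as the target, read by paw edema, with stated times of 30 min and 3 h, at a dose of 0.05 mmol/kg by the oral route (a higher number here means more inhibition at the dose given (going by the name of the read-out), a lower number less inhibition), compound 1 gives 26.6% and compound 2 gives 26.6%. For the measured compounds named here, the single measured step, no change at the digits printed from compound 1 to compound 2 (within the scatter), exchanged one aryl group for another on the shared core without moving the read-out, so compound 2 stands level with compound 1. Compound 3 `CS(=O)(=O)c1ccc(N2N=C(c3ccc(F)cc3)CCC2=O)cc1` differs from compound 2 by 4-fluorophenyl in place of 3,4-dichlorophenyl on a carbon with a double bond to nitrogen. Since that earlier aryl exchange, no change at the digits printed from compound 1 to compound 2 (within the scatter), left the number unchanged, no step beyond the scatter is expected here, and a number 1.6 percentage points lower from compound 2 to compound 3 (within the scatter) is estimated accordingly. Compound 3 is therefore expected to give 25%, within 12% to 38%.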

Compound 3, a percentage reported as inhibition, in the whole organism at one dose (the size of the read-out at that dose, not a potency): 60%
Estimate against measurement, compound 3: 35 percentage points below; the measured number lies above the stated range.
By their numbers in this assay, from the lowest: compounds 1 and 2 (each within the scatter of the next); then compound 3.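

In this assay the aryl group on the carbon with a double bond to nitrogen proves able to move the read-out: 4-fluorophenyl in place of 3,4-dichlorophenyl gives a large step (a number 33.4 percentage points higher from compound 2 to compound 3 (beyond the scatter)), and 4-fluorophenyl in place of 4-hydroxy-3-methylphenyl gives another (a number 33.4 percentage points higher from compound 1 to compound 3 (beyond the scatter)). The earlier aryl exchange showed no such movement, so this position is not indifferent to the group it carries. No measured evidence accounts for the step. The compounds shown leave open how an unsubstituted phenyl or a 4-aminophenyl would read here, and so whether the fluorine itself matters.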